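Removing the ethoxycarbonyl group: cytotoxicity of compound 3

This account rests on a few compounds, and the source may have more. Where it says the series, first, only, none or still open, it means among the compounds named here.

Of the compounds shown here, two sharing one core have been tested in an ADME assay on MT4 cells (Homo sapiens) for cytotoxicity; on this read-out lower numbers stand for higher toxicity in this test and higher numbers for lower toxicity in this test. Compound 1, `O=C(CSc1snnc1-c1ccccc1)Nc1ccccc1[N+](=O)[O-]`, carries a nitro group on the anilide ring. In this assay compound 1 reaches only the limit of the test, >= 246000 nM, and no number beyond it. Compound 2, `CCOC(=O)c1ccc(NC(=O)CSc2snnc2-c2ccccc2)c(Br)c1`, carries an ethoxycarbonyl and a bromo group on that ring. For compound 2 the read-out in this assay is likewise a limit, >= 232000 nM, so that no toxicity could be quantified within the tested range. Both values are therefore limits, as the lines the limit of >= 232000 nM in this assay, at which 1 of the 2 values shown sits, and the limit of >= 246000 nM in this assay, at which 1 of the 2 values shown sits, show, and nothing orders the two compounds against each other.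

Compound 3, `O=C(CSc1snnc1-c1ccccc1)Nc1ccccc1Br`, is obtained from compound 2 by the change (hydrogen in place of ethoxycarbonyl on an aromatic carbon). Among the measured compounds shown here, no measured step between two compounds is available on which to found a trend, so the account rests on the two limits alone. A step of about a number no higher from compound 2 to compound 3 (the limit leaves the size open) is expected, which is to say none beyond the scatter. Compound 3 is estimated to give 230000 nM in this assay, most likely again as a limit, within a range of 80000 nM to 500000 nM.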

Compound 3, half-maximal cytotoxic concentration: > 307000 nM
Compound 3: no number, only a limit (the forecaster's own chance of this, stated with the estimate: 75%); middle value at least 1.3-fold (0.12 log units) from the limit.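

For compound 3 the read-out in this assay is the limit > 307000 nM and not a number. Among the compounds shown here, with compound 1, compound 2 and compound 3 all standing at limits, no step between them can be read. The compounds shown leave open whether any of these changes on the anilide ring alters cytotoxicity in this test.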